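A Single Exchange of Chloro for Methyl

The source may hold more compounds than are shown below. What is called first, only, known or untested is meant among the compounds shown, and "the series" means these compounds.

Compound 1 `O=Cc1cn(Cc2ccc(Cl)cc2)c2ccc(F)cc12`: 290 nM
Compound 2 `O=Cc1cn(Cc2ccc(Cl)cc2)c2cc(Br)ccc12`: 90 nM
Compound 3 `OCc1cn(Cc2ccc(Cl)cc2)c2ccccc12`: 16 nM

All three values come from a functional assay on NCI-H460 cells (Homo sapiens) for cytotoxicity, read by sulforhodamine B assay, with a stated time of 3 days; on this read-out lower numbers stand for stronger inhibition and higher numbers for weaker inhibition. Compound 3, at 16 nM, has the lowest of the three numbers, and the gaps to the other two lie beyond the scatter. The nearest is compound 2, and the furthest is compound 1.

The next compound is compound 4 `Cc1ccc(Cn2cc(CO)c3ccccc32)cc1`, which has methyl in place of chloro on an aromatic carbon of a six-membered aromatic ring of carbon only, para to a large group: methyl in place of chloro on an aromatic carbon. All three measured compounds carry chloro, so the data contain no direct measure of this exchange. With so little to go on, only a modest change is expected, towards a somewhat higher number and probably not beyond the scatter. The expected step is a 1.6-fold higher number from compound 3 to compound 4 (0.19 log units; within the scatter). For compound 4 the estimated value in this assay is 25 nM, with an expected range from 8 nM to 80 nM.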

Compound 4, half-maximal inhibitory concentration: 31 nM
Compound 4: the middle estimate sits 1.2-fold (0.09 log units) below what was measured; measured number inside the range.
By their numbers in this assay, from the lowest: compounds 3 and 4 (each within the scatter of the next); then compound 2; then compound 1.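

In this assay, putting methyl in place of chloro on an aromatic carbon of the six-membered aromatic ring of carbon only, para to a large group, gives a 1.9-fold higher number from compound 3 to compound 4 (0.29 log units; within the scatter). For the compounds shown here, this pair is the only direct reading of this place, since compounds 1, 2 and 3 all carry chloro there, and it shows that chloro can be exchanged for methyl here without a change beyond the scatter. Nothing measured here speaks to the reason for this result.

As far as these compounds go, whether a methoxy, an amine or a carboxylic acid at this place would also stay within the scatter of compound 3 remains open. Also open, from the compounds shown here alone, is whether the same exchange would read alike on the core of compound 1 or compound 2.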